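The source may hold more compounds than are shown below. What is called first, only, known or untested is meant among the compounds shown, and "the series" means these compounds.

Of the compounds shown here, three sharing one core have been measured in an assay on CHO cells for displacement of a labelled ligand from adenosine receptor A1 (Homo sapiens), read by scintillation counting, with a stated time of 120 min, tested at 1 uM; a lower number here means less inhibition, a higher number more inhibition at the concentration tested (going by the name of the read-out). Compound 1 `Cc1nc2sc(-c3ccc(O)cc3)nc2c(=O)[nH]1` carries a hydroxy-bearing phenyl directly on the core, and in this assay compound 1 gives 1%. Compound 2 `Cc1nc2sc(-c3cccc(Cl)c3)nc2c(=O)[nH]1` carries a chloro-bearing phenyl directly on the core, and in this assay compound 2 gives 24%. Compound 3 `COc1ccc(Nc2nc3c(=O)[nH]c(C)nc3s2)cc1` joins a methoxy-bearing phenyl to the core through an amine, and in this assay compound 3 gives 1%.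

Compound 3 thus stands level with compound 1 at the digits shown; together they are the two lowest of the three numbers, and the gap to compound 2 is beyond the usual scatter, with compound 2 the higher.

Compound 4 `Cc1nc2sc(Nc3ccc(Cl)cc3)nc2c(=O)[nH]1` has not yet been measured. It differs from compound 3 in a single place: chloro in place of methoxy on an aromatic carbon. For the measured compounds named here, no measured pair shows this same change, so the step has to be guessed. Going by the values given here, the one chloro-bearing compound measured, compound 2, is the only one whose number stands clearly apart from the other two, with 24%, which suggests that moving to chloro may lift the number somewhat, though a step staying within the scatter is also possible. The expected change is a number 7 percentage points higher from compound 3 to compound 4 (within the scatter), a modest rise. In this assay compound 4 is therefore estimated at 8%, within a range from 0% to 25%.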

Compound 4, a percentage reported as inhibition, at one concentration (the size of the read-out at that concentration, not a potency): 33%
Compound 4: middle estimate off by 25 percentage points, on the low side; the measured number lies above the stated range.
By their numbers in this assay, from the lowest: compounds 1 and 3 (each within the scatter of the next); then compounds 2 and 4 (each within the scatter of the next).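

In this assay, chloro in place of methoxy on an aromatic carbon, para to a large group, gives a number 32 percentage points higher from compound 3 to compound 4 (beyond the scatter). For the compounds shown here, this is the first change in the set that can be read at a single place, and it shows that this position on the amine-linked phenyl is not indifferent to what it carries: the shared core, the amine link and the ring all stay the same, and the swap of one small group alone moves the number beyond the usual scatter. Nothing measured here says what lies behind the rise, so the step stands as an observation without an explanation.

The compounds shown leave open whether the rise belongs to chloro itself or would also appear with another group at this place, such as fluoro, bromo, methyl or a carboxylic acid, since only two groups have been compared here. They also leave open whether the same swap gives a similar step at another place on the ring, or on a phenyl joined to the core directly rather than through the amine.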